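Furan to pyridine on the amide of a shared core

The source may report more compounds than this note shows. Statements on the series, on what has been measured and on what is new or still open speak of the compounds shown alone.

Compound 1 `CN1CCC(C(=O)N2Cc3c(NC(=O)c4ccco4)n[nH]c3C2(C)C)CC1` carries a furan-2-yl group on the carbonyl carbon of its amide. In a functional assay on A2780 cells (Homo sapiens) for antiproliferative activity, read by fluorescence, with a stated time of 72 h (a higher number here means a weaker inhibitor, a lower number a stronger inhibitor), compound 1 gives only a limit, > 5000 nM, and not a number; it sits at the limit of > 5000 nM in this assay, at which 1 of the 2 values shown sits. Compound 2 `CCN1CCC(C(=O)N2Cc3c(NC(=O)c4ccc(F)cc4)n[nH]c3C2(C)C)CC1` differs from compound 1 in two places and is therefore not a single step from it; in this assay compound 2 gives 290 nM. Compound 3 `CN1CCC(C(=O)N2Cc3c(NC(=O)c4ccncc4)n[nH]c3C2(C)C)CC1` is not yet measured. It differs from compound 1 in one place: pyridin-4-yl in place of furan-2-yl on a carbonyl carbon. Since compound 1 stands at a limit, the size of the step cannot be fixed from the numbers shown; the author expects a move toward a stronger inhibitor, likely beyond the usual scatter, which is the step of an at least 2.5-fold lower number from compound 1 to compound 3 (0.39 log units; beyond the scatter) he estimates. In this assay compound 3 is estimated at 2000 nM, with a range from 400 nM to 10000 nM.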

Compound 3, half-maximal inhibitory concentration: 500 nM
For compound 3 the middle estimate is 4.0-fold (0.60 log units) above the measured one; the range from low to high includes it.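

On the carbonyl carbon whose other neighbour is an amide-type nitrogen, the identity of the aromatic ring proves to matter: in this assay, pyridin-4-yl in place of furan-2-yl gives an at least 10-fold lower number from compound 1 to compound 3 (1.00 log units; beyond the scatter). Both groups count one hydrogen-bond acceptor and no net charge, so these counts do not separate them, although the ring size and the hetero atom do differ. The true size of the step remains unknown, and only its lower bound can be read, because compound 1 gives a limit and not a number: the limit of > 5000 nM in this assay, at which 1 of the 3 values shown sits.

The compounds shown cannot separate the effect of ring size from that of the hetero atom, as both change in this single step. From the compounds shown here alone, how a phenyl or pyridin-3-yl group would read on the same carbonyl carbon remains open.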